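Pyrazole-benzimidazole amides: cytotoxicity notes toward compound 4

A few compounds are considered here, and "the series" means these few. Any claim that something is new, unique, unknown or untested is made for them only; others in the source may bear on it.

Three compounds of the series have been run in an ADME assay on HEK-293T cells (Homo sapiens) for cytotoxicity, read by MTT assay, with a stated time of 24 h; on this read-out higher numbers stand for lower toxicity in this test and lower numbers for higher toxicity in this test. Compound 1 `Cc1cccc(C(=O)n2c(-c3cn(-c4ccccc4)nc3-c3ccc(C(F)(F)F)cc3)nc3ccccc32)c1` gives 154000 nM, compound 2 `Cc1cncc(C(=O)n2c(-c3cn(-c4ccccc4)nc3-c3ccc(F)cc3)nc3ccccc32)c1` gives 119000 nM, and compound 3 `Cc1ccc(-c2nn(-c3ccccc3)cc2-c2nc3ccccc3n2C(=O)c2ccccc2)cc1` gives 204000 nM. The three numbers sit close together: compound 3 holds the upper end, compound 1 is nearest to it and compound 2 furthest, yet both of those gaps fall within the usual scatter of repeated measurements, so no ordering among the three can be claimed from these data.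

Compound 4 `Cc1ccc(-c2nn(-c3ccccc3)cc2-c2nc3ccccc3n2C(=O)c2cncc(C)c2)cc1` has not yet been measured in this assay. It differs from compound 3 in a single place: 5-methylpyridin-3-yl in place of phenyl on a carbonyl carbon. The same exchange on the carbonyl carbon, though combined with a different aryl group on the shared core, is already represented by compound 2, whose number in this assay lies within the scatter of compound 3.

Going by the values given here, no step between measured compounds is available for this change, so the expectation rests on the closeness of compound 2 and compound 3 in this assay and on the small size of the change. Compound 4 is therefore expected to stay within the scatter, with a 1.2-fold lower number from compound 3 to compound 4 (0.08 log units; within the scatter) not beyond it in either direction. The estimated value for compound 4 in this assay is 170000 nM, with a range of 90000 nM to 320000 nM.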

Compound 4, half-maximal cytotoxic concentration: 155000 nM
The estimate for compound 4 lay 1.1-fold (0.04 log units) above the measured number; the range from low to high includes it.
By their numbers in this assay, from the lowest: compounds 2, 1, 4 and 3 (each within the scatter of the next).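

In this assay, the exchange of phenyl for 5-methylpyridin-3-yl on a carbonyl carbon can now be read directly, with no second difference on the shared core: a 1.3-fold lower number from compound 3 to compound 4 (0.12 log units; within the scatter). Bringing in a ring nitrogen and a methyl group at this place, and with them a hydrogen-bond acceptor, therefore leaves the number within the scatter in this one matched pair. With 5-methylpyridin-3-yl held constant, the exchange of methyl for fluoro on an aromatic carbon gives a 1.3-fold higher number from compound 2 to compound 4 (0.11 log units; within the scatter), and nothing available bears on why either step stays this small.

All groups shown on the carbonyl carbon are six-membered aromatic rings, so it remains open whether a morpholine, a carboxylic acid or a longer alkyl chain at this place would give a step beyond the scatter. From the compounds shown here alone, the phenyl on the pyrazole-linked shared core is also the same in all four compounds, and the effect of replacing it with an amine or a pyridine remains equally open.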